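Adding a Cyano Group to Compound 2

The source may hold more compounds than are shown below. What is called first, only, known or untested is meant among the compounds shown, and "the series" means these compounds.

Measured so far:
Compound 1 `O=C(CCc1cccc2c1B(O)OC2)NC1CCCCC1`: > 100000 nM, which is a limit of the assay, not a number.
Compound 2 `O=C(CCc1cccc2c1B(O)OC2)Nc1cccc(-c2ccccc2)c1`: 890 nM.

Among the compounds with values here, in a functional assay on HCT-116 cells (Homo sapiens) for antiproliferative activity, read by MTT assay, with a stated time of 72 h (a lower number here means a stronger inhibitor, a higher number a weaker inhibitor), compound 2 holds the only real number; the other entry is a limit (the limit of > 100000 nM in this assay, at which 1 of the 2 values shown sits). Compound 3 `N#Cc1cccc(-c2cccc(NC(=O)CCc3cccc4c3B(O)OC4)c2)c1` differs from compound 2 by cyano in place of hydrogen on an aromatic carbon. Within the data shown here, no step between measured compounds is known, so the size of this change cannot be read from the data. Such a small addition is expected to move the number little, with compound 3 estimated at 1000 nM, between 300 nM and 4000 nM. The expected step of a 1.1-fold higher number from compound 2 to compound 3 (0.05 log units; within the scatter) is therefore within or just beyond the scatter.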

Compound 3, half-maximal inhibitory concentration: 140 nM
The estimate for compound 3 lay 7.1-fold (0.85 log units) above the measured number, outside the stated range (below it).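

Going from phenyl to 3-cyanophenyl gives a 6.4-fold lower number from compound 2 to compound 3 (0.80 log units; beyond the scatter) in this assay, the first change in this series whose size can be read. This carbon of the aromatic ring is therefore not indifferent to what it carries, since even a small group placed there moves the number beyond the usual scatter. Nothing in the data shown explains why the number falls.

As far as these compounds go, whether this drop belongs to cyano itself remains open, and an amine, a carboxylic acid or a methoxy group at the same carbon would help to settle that. Also open, from the compounds shown here alone, is whether cyano would act alike on other carbons of this ring.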